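Swapping One Aromatic Group on a Shared Core

The compounds below may be only part of what the source reports. "The series", "measured", "known", "first", "only" and "open" are said of these compounds alone.

In an ADME assay on NHDF cells (Homo sapiens) for cytotoxicity, read by MTT assay, with a stated time of 72 h (a lower number here means a stronger inhibitor, a higher number a weaker inhibitor), compound 1 (`COc1cccc(/C=C2\CCC/C(=C\c3ccc(O)c(Cl)c3)C2=O)c1OC`) gives 39500 nM and compound 2 (`COc1ccc(/C=C2\CCC/C(=C\c3ccccc3Br)C2=O)cc1OC`) gives 21800 nM as its measured value. These two numbers sit within the usual scatter of repeated measurements, so compound 2 stands level with compound 1 and no order can be read between them.

Compound 3 (`COc1ccc(/C=C2\CCC/C(=C\c3cccc(Cl)c3Cl)C2=O)cc1OC`) still awaits measurement. It differs from compound 2 in one place (2,3-dichlorophenyl in place of 2-bromophenyl on a double-bonded chain carbon bound to a double-bonded ring carbon) with 2,3-dichlorophenyl in place of 2-bromophenyl on a double-bonded chain carbon bound to a double-bonded ring carbon. Within the data shown here, no measured pair of compounds differs in only one place, so no measured step is available as a guide. The only hint is the narrow spread so far, with compound 1 at 39500 nM and compound 2 at 21800 nM in the same test.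

The expected change is a 1.1-fold lower number from compound 2 to compound 3 (0.04 log units; within the scatter) and it is estimated to stay within the scatter, with no clear direction. Compound 3 is estimated at 20000 nM in this assay with an expected range from 9000 nM to 45000 nM for its value.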

Compound 3, half-maximal inhibitory concentration: 18500 nM
Estimate against measurement, compound 3: 1.1-fold (0.03 log units) above, and the stated range covers the measured number.
By their numbers in this assay, from the lowest: compounds 3, 2 and 1 (each within the scatter of the next, the first and the last beyond it).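

On a double-bonded chain carbon bound to a double-bonded ring carbon, putting 2,3-dichlorophenyl in place of 2-bromophenyl gives a 1.2-fold lower number from compound 2 to compound 3 (0.07 log units; within the scatter) in this assay, so the two compounds stand level. Among these compounds, this is the first pair that differs in only one place, which allows this position to be read directly, something the comparison of compound 1 with compound 2 could not do because those two differ in more than one place. For this one exchange, a phenyl carrying bromine and a phenyl carrying two chlorines give readings that cannot be told apart, but no supporting measurement offers an explanation for that.

The compounds shown leave open whether a group of a different kind at this position, such as an amine or a carboxylic acid on the phenyl ring, would shift the number beyond the scatter. They also leave open whether this level result would hold if the dimethoxyphenyl group on the other side of the shared core were replaced, since compound 2 and compound 3 both carry it.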